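Swapping Piperidinyl for Morpholinyl on Two Related Cores

This account rests on a few compounds, and the source may have more. Where it says the series, first, only, none or still open, it means among the compounds named here.

Compound 1 `Cc1ccc2c(=O)c(CSC(=S)N3CCCCC3)coc2c1` and compound 2 `Cc1ccc2c(=O)c(CSC(=S)N3CCOCC3)coc2c1` share one core and differ only in the ring attached to a thiocarbonyl carbon. In a functional assay on MDA-MB-435S cells (Homo sapiens) for antiproliferative activity, read by MTT assay, with a stated time of 72 h (a higher number here means a weaker inhibitor, a lower number a stronger inhibitor), compound 1 gives 1700 nM, while compound 2 gives 5500 nM. The change between them is morpholin-4-yl in place of piperidin-1-yl on a thiocarbonyl carbon, and it produced the step of a 3.2-fold higher number from compound 1 to compound 2 (0.51 log units; beyond the scatter).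

Compound 3 `CCOC(=O)c1cc(=O)c2cc(CSC(=S)N3CCCCC3)ccc2o1` is built on a second core; the difference between the two cores is not broken down here. In this assay compound 3 gives 2900 nM, a value that lies within the usual scatter of both compound 1 and compound 2. Compound 4 `CCOC(=O)c1cc(=O)c2cc(CSC(=S)N3CCOCC3)ccc2o1` carries, on this second core, the same change that separates compound 2 from compound 1: morpholin-4-yl in place of piperidin-1-yl on a thiocarbonyl carbon. The place of the change is described in the same words for both pairs, so it is the same change made in a new setting.

Among the compounds with values here, since the only measured example of this change is the step of a 3.2-fold higher number from compound 1 to compound 2 (0.51 log units; beyond the scatter), a step of similar size is expected for the new pair, and the estimate for the step from compound 3 to compound 4 is a 2.9-fold higher number from compound 3 to compound 4 (0.47 log units; beyond the scatter). Compound 4 is accordingly expected to give 8500 nM in this assay, with a likely range from 4000 nM to 18000 nM. This expectation rests on a single measured pair and on a change carried over to a different core, so the range is kept wide.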

Compound 4, half-maximal inhibitory concentration: > 25000 nM
Compound 4: no number, only a limit; the forecaster's own chance of this, stated with the estimate: 5%; middle value at least 2.9-fold (0.46 log units) away from the limit.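

In this assay compound 4 gives > 25000 nM, which is a limit of the assay and not a number. Morpholin-4-yl in place of piperidin-1-yl on a thiocarbonyl carbon gives a higher number on the second core too, with an at least 8.6-fold higher number from compound 3 to compound 4 (0.93 log units; beyond the scatter), so in these two pairs the direction of the step carries over from one core to the other. This does not show that the change has the same size on both cores, and two pairs are too few to make a rule for the series: the same change on two cores in this assay, a 3.2-fold higher number (0.51 log units; beyond the scatter) from compound 1 to compound 2 and an at least 8.6-fold higher number (0.93 log units; beyond the scatter) from compound 3 to compound 4; the limit leaves it open whether they differ

The compounds shown carry only piperidin-1-yl or morpholin-4-yl at the thiocarbonyl carbon, so it stays open how a piperazine ring, or an open-chain amine such as diethylamine, would behave there on either core. From the compounds shown here alone, it also stays open whether the step would keep its direction on a core with a carboxylic acid in place of the ethyl ester of compound 3 and compound 4.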